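Butyl in Place of Isopropyl on a Shared Core

The compounds below may be only part of what the source reports. "The series", "measured", "known", "first", "only" and "open" are said of these compounds alone.

Compound 1 `Cc1ccc(Nc2ccc3c(c2)C(O)(CCC(C)C)C(=O)N3)cc1` gives 22700 nM in a functional assay on NCI-H460 cells (Homo sapiens) for antiproliferative activity, read by MTT assay, with a stated time of 48 h; on this read-out higher numbers stand for weaker inhibition and lower numbers for stronger inhibition. Compound 3 `CC(C)CCC1(O)C(=O)Nc2ccc(Nc3ccc(Cl)cc3)cc21` gives 25000 nM. Compound 2 `CCCCCCC1(O)C(=O)Nc2ccc(Nc3ccc(C)cc3)cc21` reaches only a limit of the assay, > 100000 nM.

Compounds 1 and 3 differ by chloro in place of methyl on an aromatic carbon, and the step is a 1.1-fold higher number from compound 1 to compound 3 (0.04 log units; within the scatter). Compounds 1 and 2 differ by butyl in place of isopropyl on a saturated chain carbon, two bonds along the chain from a saturated ring carbon, and the step is an at least 4.4-fold higher number from compound 1 to compound 2 (0.64 log units; beyond the scatter), with compound 2 resting at the limit of > 100000 nM in this assay, at which 1 of the 3 values shown sits.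

Compound 4 `CCCCCCC1(O)C(=O)Nc2ccc(Nc3ccc(Cl)cc3)cc21` is not yet measured. It differs from compound 3 by butyl in place of isopropyl on a saturated chain carbon, two bonds along the chain from a saturated ring carbon, the same change as from compound 1 to compound 2, made on the core of compound 3. From compound 3 to compound 4 a step of about a 4.8-fold higher number from compound 3 to compound 4 (0.68 log units; beyond the scatter) is expected, because the same change gave an at least 4.4-fold higher number from compound 1 to compound 2 (0.64 log units; beyond the scatter). Compound 4 is therefore estimated at 120000 nM, likely again a limit rather than a number.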

Compound 4, half-maximal inhibitory concentration: 30300 nM
Estimate against measurement, compound 4: 4.0-fold (0.60 log units) above; measured number below the stated range.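

In this assay, butyl in place of isopropyl does not carry over evenly from one core to the other, as a 1.2-fold higher number from compound 3 to compound 4 (0.08 log units; within the scatter) stands apart from the earlier step: the same change on two cores in this assay, an at least 4.4-fold higher number (0.64 log units; beyond the scatter) from compound 1 to compound 2 and a 1.2-fold higher number (0.08 log units; within the scatter) from compound 3 to compound 4, at least 3.6-fold (0.56 log units) apart, beyond the scatter of two such steps. Chloro in place of methyl also depends on its partner change, with an at least 3.3-fold lower number from compound 2 to compound 4 (0.51 log units; beyond the scatter) set against the earlier step: the same change on two cores in this assay, a 1.1-fold higher number (0.04 log units; within the scatter) from compound 1 to compound 3 and an at least 3.3-fold lower number (0.51 log units; beyond the scatter) from compound 2 to compound 4, at least 3.6-fold (0.56 log units) apart, beyond the scatter of two such steps. Compound 2 rests at a limit of the assay, > 100000 nM, and not at a number; the true size of both gaps stays unknown, and these four compounds give no reason for them.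

From the compounds shown here alone, whether an octyl chain at this place, or a methoxy or a carboxylic acid in place of the chloro, would follow either pattern remains open.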